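The source may report more compounds than this note shows. Statements on the series, on what has been measured and on what is new or still open speak of the compounds shown alone.

Working notes on the series. Compound 1 `Cc1cc(O)c(C(=O)/C=C/c2ccc(Br)cc2)c(-c2ccc(OCc3ccccc3)cc2)c1C(=O)/C=C/c1ccc(Br)cc1` gives 20000 nM in an ADME assay on HEK293 cells (Homo sapiens) for cytotoxicity, read by MTT assay, with a stated time of 24 h; a higher number here means a weaker inhibitor, a lower number a stronger inhibitor. Compound 2 `Cc1cc(O)c(C(=O)/C=C/c2ccc(OCc3ccccc3)cc2)c(-c2ccccc2)c1C(=O)/C=C/c1ccc(OCc2ccccc2)cc1` gives 30000 nM in this assay, and compound 3 `Cc1cc(O)c(C(=O)/C=C/c2ccc(OCc3ccccc3)cc2)c(-c2ccc(OCc3ccccc3)cc2)c1C(=O)/C=C/c1ccc(OCc2ccccc2)cc1` gives 30000 nM in this assay; all three values sit within the usual scatter of one another. Compound 3 and compound 2 differ by hydrogen in place of benzyloxy on an aromatic carbon, and the step is no change at the digits printed from compound 3 to compound 2 (within the scatter). The difference between the cores of compound 1 and compound 3 is not broken down here. Compound 4 `Cc1cc(O)c(C(=O)/C=C/c2ccc(Br)cc2)c(-c2ccccc2)c1C(=O)/C=C/c1ccc(Br)cc1` remains to be measured; it differs from compound 1 by hydrogen in place of benzyloxy on an aromatic carbon, the same change at the same kind of place. The step in this assay is expected to be no change at the digits printed from compound 1 to compound 4 (within the scatter), because no change at the digits printed from compound 3 to compound 2 (within the scatter). Compound 4 is accordingly estimated at 20000 nM, with a likely range from 10000 nM to 40000 nM.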

Compound 4, half-maximal inhibitory concentration: 10000 nM
The estimate for compound 4 lay 2.0-fold (0.30 log units) above the measured number; low and high end bracket the measured number.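

Hydrogen in place of benzyloxy on an aromatic carbon gives a 2.0-fold lower number from compound 1 to compound 4 (0.30 log units; within the scatter) in this assay. Set beside the earlier step, the change reads alike on the two cores: the same change on two cores in this assay, no change at the digits printed (within the scatter) from compound 3 to compound 2 and a 2.0-fold lower number (0.30 log units; within the scatter) from compound 1 to compound 4, 2.0-fold (0.30 log units) apart, within the scatter of two such steps. This shows that the change carries between the core of compound 3 and the core of compound 1 without a gap beyond the scatter, but it does not show that it would carry to any other core, and with both steps inside the scatter a small real effect can be neither claimed nor excluded.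

The compounds shown leave open how an amine, a carboxylic acid or a longer alkoxy chain on that aromatic carbon would read in this assay. They also leave open whether a core bearing a nitrile in place of the bromine would follow the same step.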